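The source may report more compounds than this note shows. Statements on the series, on what has been measured and on what is new or still open speak of the compounds shown alone.

Measured so far:
- compound 1, `CC(=O)Nc1nc(-c2cccc(NS(=O)(=O)c3cccc(Br)c3)c2)cs1`: 67.4%
- compound 2, `CC(=O)Nc1nc(-c2cccc(NS(=O)(=O)c3ccc(C#CCO)cc3)c2)cs1`: 99.3%
- compound 3, `CC(=O)Nc1nc(-c2cccc(NS(=O)(=O)c3ccc(C#C[Si](C)(C)C)cc3)c2)cs1`: 4.2%

All three were tested in a functional assay on A-375 cells (Homo sapiens) for antiproliferative activity, read by trypan blue exclusion, with a stated time of 48 h, tested at 5 uM; on this read-out lower numbers stand for a stronger effect and higher numbers for a weaker effect at the one concentration tested. In this assay compound 3 gives 4.2%, the lowest number of the three, and its distance to the others is beyond the scatter: compound 1 gives 67.4% and compound 2 gives 99.3%. On these numbers compound 3 therefore shows the strongest effect.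

The next compound, compound 4, `CC(=O)Nc1nc(-c2cccc(NS(=O)(=O)c3ccc(C#CCCc4ccccc4)cc3)c2)cs1`, differs from compound 3 in one place: a group of 8 heavy atoms (8 carbon; one six-membered aromatic ring of carbon only) in place of a group of 4 heavy atoms (3 carbon, 1 silicon; no ring), on a triple-bonded carbon. For the measured compounds named here, the one measured step that touches the same position is a number 95.1 percentage points lower from compound 2 to compound 3 (beyond the scatter), a large drop, which shows that this assay reacts strongly to what is attached to the triple-bonded carbon. Compound 4 replaces the silicon-containing group with a phenethyl chain, a group that, like the one it replaces, carries no hydrogen-bond donors or acceptors, but which is larger and carbon-only. Given how much the read-out moved in the step from compound 2 to compound 3, a change beyond the scatter is expected here too, most likely upward from compound 3, though of uncertain size. Compound 4 is therefore estimated at 30%, with a plausible range from 5% to 80%, which would mean an expected step of a number 25.8 percentage points higher from compound 3 to compound 4 (beyond the scatter).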

Compound 4, a percentage reported as activity, at one concentration (the size of the read-out at that concentration, not a potency): 4.2%
Beside the measured number, compound 4's estimate is 25.8 percentage points above it, outside the stated range (below it).
By their numbers in this assay, from the lowest: compounds 3 and 4 (each within the scatter of the next); then compound 1; then compound 2.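

In this assay, putting phenethyl on the triple-bonded carbon in place of the silicon-containing group gives no change at the digits printed from compound 3 to compound 4 (within the scatter), so two groups that differ this much in size and make-up read the same here, and the low number of compound 3 does not depend on silicon. The other new comparison, benzyl in place of hydroxy on a saturated chain carbon bound to a triple-bonded carbon, gives a number 95.1 percentage points lower from compound 2 to compound 4 (beyond the scatter) and so adds a second large step away from the hydroxy-bearing compound, next to a number 95.1 percentage points lower from compound 2 to compound 3 (beyond the scatter). No other data bear on why the hydroxy compound stands so far from the two groups without hydrogen-bond donors or acceptors.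

On these data alone, what an amine or a carboxylic acid on the triple-bonded carbon would do remains open, as does whether a group as small as methyl would give the same reading as phenethyl. As far as these compounds go, with only one concentration, it also remains open whether compound 3 and compound 4 would separate at lower concentrations.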